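This account rests on a few compounds, and the source may have more. Where it says the series, first, only, none or still open, it means among the compounds named here.

Measured in a functional assay on HT-29 cells (Homo sapiens) for antiproliferative activity, read by MTT assay, with a stated time of 48 h; a higher number here means a weaker inhibitor of growth, a lower number a stronger inhibitor of growth:
- Compound 1 `CCCOC(=O)N1N=C(c2ccccc2)CC1c1cc(OC)c(OC)c(OC)c1`: > 10000 nM, a limit
- Compound 2 `COc1cc(C2CC(c3ccccc3)=NN2C(=O)OCc2ccccc2)cc(OC)c1OC`: > 10000 nM, a limit
- Compound 3 `CCOC(=O)N1N=C(c2cccc(OC)c2)CC1c1cc(OC)c(OC)c(OC)c1`: 7860 nM

Compound 2 has no number, only a limit of > 10000 nM. Compound 1 and compound 2 both sit at the limit of > 10000 nM in this assay, at which 2 of the 3 values shown sit.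

Compound 4 `COc1cccc(C2=NN(C(=O)OCc3ccccc3)C(c3cc(OC)c(OC)c(OC)c3)C2)c1` is compound 2 with one change, methoxy in place of hydrogen on an aromatic carbon, so that phenyl becomes 3-methoxyphenyl.

Within the data shown here, the only measured step, a step that the two limits leave unreadable from compound 1 to compound 2, concerns a different part of the molecule and gives no readable size. Among the measured compounds shown here, the one hint comes from compound 3, which carries the same 3-methoxyphenyl group and gives a number, 7860 nM. For the measured compounds named here, no matched step isolates the methoxy group, so the expectation in this assay is only a modest shift towards stronger growth inhibition, and compound 4 may well remain at the limit.

The expected step is an at least 1.2-fold lower number from compound 2 to compound 4 (0.09 log units; that floor lies within the scatter). For compound 4 the estimate is 8000 nM, with an expected range from 3000 nM to 20000 nM.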

Compound 4, concentration for 50% growth inhibition: > 10000 nM
Compound 4: no number, only a limit; the forecaster's own chance of this, stated with the estimate: 50%; middle value at least 1.2-fold (0.09 log units) from the limit.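

In this assay compound 4 gives > 10000 nM, a limit and not a number. The new change, phenyl to 3-methoxyphenyl, therefore does not bring this compound to a measured value, and neither the step that adds the methoxy nor the earlier step between limits can be read. Among these compounds, the only readable new step, phenyl in place of methyl with the 3-methoxyphenyl group held constant, is an at least 1.2-fold higher number from compound 3 to compound 4 (0.10 log units; that floor lies within the scatter), so it establishes no real difference and says nothing about the methoxy group itself.

Most of the series cannot be ranked in this assay: the limit of > 10000 nM in this assay, at which 3 of the 4 values shown sit. Whether an amine or a carboxylic acid in place of methoxy on this aromatic ring would give a measured value remains open.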